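Cytotoxicity of a bromo analogue of compound 1

The compounds below may be only part of what the source reports. "The series", "measured", "known", "first", "only" and "open" are said of these compounds alone.

Compound 1, `CCCCOc1ccc(-c2c(NC(C)(C)CC(C)(C)C)nc3ncccn23)cc1`: 49000 nM in a toxicity assay on A549 cells (Homo sapiens) for cytotoxicity, read by luminescence and CellTiter-Glo, with a stated time of 48 h; a higher number here means that more compound is tolerated, a lower number that less compound is tolerated
Compound 2, `CCCCOc1ccc(-c2c(N)nc3ncccn23)cc1`: > 100000 nM in this assay

In this assay, going by the values given here, compound 1 gives 49000 nM, the only number in the set. Compound 2 reaches only the limit of the assay, > 100000 nM, which is a limit and not a number. Among the compounds with values here, the single measured step, an at least 2.0-fold higher number from compound 1 to compound 2 (0.30 log units; that floor lies within the scatter), replaces hydrogen for 1,1,3,3-tetramethylbutyl on a nitrogen on an aromatic ring, and its size is bounded only by the limit of > 100000 nM in this assay, at which 1 of the 2 values shown sits.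

Compound 3, `CC(C)(C)CC(C)(C)Nc1nc2ncccn2c1-c1ccc(Br)cc1`, differs from compound 1 by bromo in place of butoxy on an aromatic carbon. Within the data shown here, no measured step touches that aromatic carbon; the only step known changes the nitrogen substituent. For compound 3 no change beyond the scatter is therefore expected, and the step of a 1.0-fold higher number from compound 1 to compound 3 (0.01 log units; within the scatter) is estimated to be small. Compound 3 is expected to give about 50000 nM, within 15000 nM to 150000 nM.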

Compound 3, half-maximal cytotoxic concentration: > 100000 nM
Compound 3: a limit, no number; the forecaster's own chance of this, stated with the estimate: 30%; middle value at least 2.0-fold (0.30 log units) away from the limit.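

Going by these compounds alone, compound 3 carries the first change at this aromatic carbon, and bromo in place of butoxy gives an at least 2.0-fold higher number from compound 1 to compound 3 (0.30 log units; that floor lies within the scatter). In this assay compound 3 reaches > 100000 nM, which is a limit and not a number. The step thus shows that this position, like the nitrogen substituent, can carry a single change from compound 1 that ends at the limit, but its true size cannot be read because only a floor is given: the limit of > 100000 nM in this assay, at which 2 of the 3 values shown sit.

The compounds shown leave open whether a shorter ether such as methoxy, a longer chain, or an amine on this aromatic carbon would give a number in this assay rather than a limit. They also leave open how far butoxy itself matters, since a plain hydrogen at this place is not among them.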